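The source may report more compounds than this note shows. Statements on the series, on what has been measured and on what is new or still open speak of the compounds shown alone.

In a functional assay on A549 cells (Homo sapiens) for cytotoxicity (a higher number here means that more compound is needed for the effect, a lower number that less compound is needed), compound 1 `COC1=C(C)C(=O)/C(=C(O)/C=C/c2ccc(F)cc2)C(=O)C1(C)C` gives 3.3 ug/mL, at the low end of the three measured numbers. Compound 2 `CCc1ccc(/C=C/C(O)=C2/C(=O)C(C)=C(OC)C(C)(C)C2=O)cc1` gives 6.1 ug/mL, within the scatter of compound 1, while compound 3 `COC1=C(C)C(=O)/C(=C(O)/C=C/c2c(C)cc(C)cc2C)C(=O)C1(C)C` gives 8 ug/mL, beyond the scatter on the higher side of compound 1. Compound 4 `C=Cc1ccccc1/C=C/C(O)=C1/C(=O)C(C)=C(OC)C(C)(C)C1=O` has not been measured, and its difference from compound 1 is 2-vinylphenyl in place of 4-fluorophenyl on a double-bonded chain carbon bound to a double-bonded chain carbon. Going by the values given here, one measured step bears on this change, also a swap on the aromatic ring: a 1.8-fold higher number from compound 1 to compound 2 (0.27 log units; within the scatter). Going by that small step, a similarly modest rise is expected, and the estimated step is a 1.8-fold higher number from compound 1 to compound 4 (0.26 log units; within the scatter). The estimate for compound 4 is 6 ug/mL, with an expected range from 2.5 ug/mL to 14 ug/mL.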

Compound 4, concentration for half-maximal effect: 2.2 ug/mL
Compound 4: the middle estimate sits 2.7-fold (0.44 log units) above what was measured; the measured number lies below the stated range.
By their numbers in this assay, from the lowest: compounds 4, 1, 2 and 3 (each within the scatter of the next, the first and the last beyond it).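

In this assay, 2-vinylphenyl in place of 4-fluorophenyl gives a 1.5-fold lower number from compound 1 to compound 4 (0.18 log units; within the scatter), so this larger group is accommodated at this position without a change beyond the scatter. Against 4-ethylphenyl, the same group gives a 2.8-fold lower number from compound 2 to compound 4 (0.44 log units; beyond the scatter), the first step between compounds differing in one place to lie beyond the scatter. No measurement shown here accounts for either step. The compounds shown change the vinyl group and its ring position together, so their separate contributions remain open. As far as these compounds go, how a phenyl carrying an amine or a carboxylic acid would read here also remains open.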